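A Single Methyl on a Furan Ring

This account rests on a few compounds, and the source may have more. Where it says the series, first, only, none or still open, it means among the compounds named here.

In a functional assay on DU-145 cells (Homo sapiens) for cytotoxicity, in the presence of a further agent that is not named here (a higher number here means a weaker inhibitor, a lower number a stronger inhibitor), compound 1 `Clc1ccc(-c2cc(-c3ccsc3)nc(-c3ccco3)c2)o1` gives 18900 nM. Two relatives have also been measured: compound 2 `Clc1ccc(-c2cc(-c3cccnc3)nc(-c3cccs3)c2)o1` gives 13000 nM, and compound 3 `Clc1ccc(-c2cc(-c3ccoc3)cc(-c3ccsc3)n2)cc1` gives 37600 nM. The value for compound 1 lies within the usual scatter of both, so these data do not separate it from either one.

Compound 4 `Cc1ccc(-c2cc(-c3ccc(Cl)o3)cc(-c3ccsc3)n2)o1` has not yet been measured. It differs from compound 1 in one place: methyl in place of hydrogen on an aromatic carbon. This is methyl in place of hydrogen on an aromatic carbon, next to the ring oxygen of a five-membered aromatic ring with 1 oxygen. The same difference can be read as furan-2-yl to 5-methylfuran-2-yl.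

Within the data shown here, no measured pair here shows this change or any other single change, so the data offer no direct guide to its effect. The expectation therefore rests on the closeness of compound 1 at 18900 nM to compound 2 at 13000 nM. In this assay, no step beyond the scatter is expected, and neither direction is favoured. The estimated change is a 1.1-fold lower number from compound 1 to compound 4 (0.05 log units; within the scatter). Compound 4 is expected to give about 17000 nM, with an estimated range of 7500 nM to 38000 nM.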

Compound 4, half-maximal inhibitory concentration: 18500 nM
Beside the measured number, compound 4's estimate is 1.1-fold (0.04 log units) below it; the measured number falls inside the stated range.
By their numbers in this assay, from the lowest: compounds 2, 4, 1 and 3 (each within the scatter of the next, the first and the last beyond it).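

In this assay, the methyl on an aromatic carbon of the furan ring, next to the ring oxygen, gives a 1.0-fold lower number from compound 1 to compound 4 (0.01 log units; within the scatter), so the two compounds cannot be told apart. Among these compounds, this is the first pair here that differs in a single place, and it turns the earlier indirect comparison into a direct reading: for this pair, furan-2-yl and 5-methylfuran-2-yl give the same result within the scatter. The finding covers only this one added carbon on this one core, and no measurement here offers a reason for the result.

The compounds shown leave open whether this position would read the same with a larger or very different group, such as a longer chain, an amine or a carboxylic acid. They also leave open whether the same methyl would give a similar reading on the core of compound 2 or of compound 3, which carry other rings.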